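This account rests on a few compounds, and the source may have more. Where it says the series, first, only, none or still open, it means among the compounds named here.

Measured so far:
compound 1 `CC(Oc1ccc(Oc2ccc(Cl)cc2)cc1)C(=O)Cn1nnc(-c2ccc(Cl)cc2)n1` — < 5%
compound 2 `CC(Oc1ccc(Oc2ccc(C(F)(F)F)cc2)cc1)C(=O)Cn1nnc(-c2ccc(Cl)cc2)n1` — 9%

In an ADME assay on S9 fraction from liver (Rattus norvegicus) for metabolic stability, read by LC-MS, using NADPH, with a stated time of 30 min (a lower number here means that less of the compound is left, a higher number that more of the compound is left), compound 1 gives < 5%, a limit of the assay rather than a number (the limit of < 5% in this assay, at which 1 of the 2 values shown sits). In this assay compound 2 gives 9%. Among the compounds with values here, the only measured step, a number at least 4 percentage points higher from compound 1 to compound 2 (that floor lies within the scatter), swaps one halogen-type group for trifluoromethyl and does not bear directly on the change now considered.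

Compound 3 `CC(Oc1ccc(Oc2ccc(Cl)cc2)cc1)C(=O)Cn1nnc(-c2ccc(C(=O)O)cc2)n1` differs from compound 1 as follows: carboxy in place of chloro on an aromatic carbon. Within the data shown here, with compound 1 known only as a limit, no measured step anchors a direction. A rise no larger than the scatter is expected, a number at least 5 percentage points higher from compound 1 to compound 3 (that floor lies within the scatter). Compound 3 is therefore estimated at 10%, between 2% and 30%.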

Compound 3, percent of the compound remaining in the Rattus norvegicus assay: 32%
For compound 3 the middle estimate is 22 percentage points below the measured one; measured number above the stated range.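

In the Rattus norvegicus assay, the change from 4-chlorophenyl to 4-carboxyphenyl gives a number at least 27 percentage points higher from compound 1 to compound 3 (beyond the scatter), so this position can shift the read-out by more than the scatter, which the earlier step could not show. In the Rattus norvegicus assay compound 1 gives < 5%, which is a limit of the assay and not a number. In a physicochemical assay for lipophilicity, read by HPLC, tested at 5 mM (a lower number here means a more polar compound, a higher number a more lipophilic compound), compound 1 gives 6.8 and compound 3 gives 3.3. In the physicochemical assay the same change also leaves compound 3 far more polar: the measured partition coefficient of compound 1, 6.8, and of compound 3, 3.3, a number 3.50 log units lower (beyond the scatter)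

The compounds shown do not separate the fall in partition coefficient from the carboxy group itself. A primary amide, a nitrile or an amine at this position would bear on that.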